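Aminophenyl Gives Way to Pyrrolidine on a Shared Core

The compounds below may be only part of what the source reports. "The series", "measured", "known", "first", "only" and "open" are said of these compounds alone.

Compound 1 `Nc1cccc(CNc2cc(C(F)(F)F)cc3[nH]ncc23)c1` stands highest of the three compounds measured in an assay for inhibition of Tryptophan 2,3-dioxygenase (Homo sapiens), with stated times of 10 min and 60 min, tested at 10 uM (on this read-out lower numbers stand for a weaker effect and higher numbers for a stronger effect at the one concentration tested), where compound 1 gives 68%. Compound 3 `CC(C)n1ncc2c(NCc3ccccc3[N+](=O)[O-])cc(C(F)(F)F)cc21` comes nearest to it, and in this assay compound 3 gives 35%, a number beyond the scatter below that of compound 1. Compound 2 `O=C1NCc2c(NCc3ccccc3[N+](=O)[O-])cccc21` lies furthest away; in this assay compound 2 gives 23%, also beyond the scatter below compound 1.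

Compound 4 `FC(F)(F)c1cc(NC[C@H]2CCCN2)c2cn[nH]c2c1` has not yet been measured. It differs from compound 1 in one place: pyrrolidin-2-yl in place of 3-aminophenyl on a saturated chain carbon bound to a nitrogen on an aromatic ring. For the measured compounds named here, no two measured compounds differ in only one place, so no measured step guides this change, and compounds 2 and 3 carry other groups altogether. Since the aromatic ring of compound 1 leaves and a five-membered non-aromatic ring enters on the saturated chain carbon, the step in this assay is expected to run downward and beyond the scatter, with a number 28 percentage points lower from compound 1 to compound 4 (beyond the scatter) as its estimated size. For compound 4 the expected read-out in this assay is 40%, within a range from 15% to 65%.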

Compound 4, a percentage reported as inhibition, at one concentration (the size of the read-out at that concentration, not a potency): 55%
The estimate for compound 4 lay 15 percentage points below the measured number; low and high end bracket the measured number.
By their numbers in this assay, from the lowest: compound 2; then compound 3; then compound 4; then compound 1.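

For the compounds shown here, the first comparison of compounds differing in one place shows that, on a saturated chain carbon bound to a nitrogen on an aromatic ring, replacing 3-aminophenyl with pyrrolidin-2-yl gives a number 13 percentage points lower from compound 1 to compound 4 (beyond the scatter) in this assay and thus a modest loss. A six-membered aromatic ring of carbon only is therefore not required here for a clear read-out, as compound 4 with its five-membered non-aromatic ring still gives 55% at the one concentration tested. No measurement shown bears on why the step has this size. The compounds shown leave open how a piperidin-2-yl group, a cyclopentyl group or an open-chain amine would read at this place. They also leave open how the mirror-image form of pyrrolidin-2-yl would compare with compound 4 in this assay at this concentration.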